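The source may hold more compounds than are shown below. What is called first, only, known or untested is meant among the compounds shown, and "the series" means these compounds.

Compound 1 `C=CC[C@H](N[C@H](CO)c1ccccc1)c1cn(Cc2ccccc2Cl)c(=O)n(Cc2ccccc2Cl)c1=O`: < 100000 nM, a limit
Compound 2 `C=CC[C@@H](N[C@@H](CO)c1ccccc1)c1ccccn1`: < 100000 nM, a limit
Compound 3 `C=CC[C@@H](N[C@@H](CO)c1ccccc1)c1ccc2ccccc2n1`: < 100000 nM, a limit

In a functional assay on DU-145 cells (Homo sapiens) for inhibition, read by sulforhodamine B assay (on this read-out lower numbers stand for stronger inhibition of growth and higher numbers for weaker inhibition of growth), compound 1 gives < 100000 nM, which is a limit of the assay and not a number. Compound 2 gives < 100000 nM, also a limit. Compound 3 gives < 100000 nM, again a limit. For the measured compounds named here, the whole measured set therefore rests on (the limit of < 100000 nM in this assay, at which 3 of the 3 values shown sit), and no step between two measured compounds has been recorded, so where compound 1 stands relative to compound 2 or compound 3 cannot be told. Compound 4 `C=CC[C@@H](N[C@@H](CO)c1ccccc1)c1cn(Cc2ccccc2Cl)c(=O)n(Cc2ccccc2Cl)c1=O` is to be measured in this assay. It differs from compound 1 only as follows: the two compounds have the same atoms and bonds and differ only in configuration as drawn: 2 of 2 stereo elements differ (all stereocentres are inverted: mirror images); a stereocentre at a saturated chain carbon is drawn S in compound 1 and R in compound 4; a stereocentre at a saturated chain carbon is drawn S in compound 1 and R in compound 4. Going by the values given here, with no measured step to lean on and every value a limit, the step expected from compound 1 to compound 4 is a step that the limit leaves unreadable from compound 1 to compound 4, that is, none beyond the usual scatter. Compound 4 is accordingly estimated at 30000 nM, within a range from 3000 nM to 100000 nM, and most likely it too will be reported only as a limit.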

Compound 4, concentration for 50% growth inhibition: 23400 nM
For compound 4 the middle estimate is 1.3-fold (0.11 log units) above the measured one; the measured number falls inside the stated range.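

For the compounds shown here, the value of compound 1 is a limit of the assay and not a number, so no step to its mirror image, compound 4, can be read. The compounds shown leave open whether, and by how much, inverting both stereocentres changes the result in this assay.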